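The source may report more compounds than this note shows. Statements on the series, on what has been measured and on what is new or still open speak of the compounds shown alone.

Three compounds have been measured in a functional assay on A549 cells (Homo sapiens) for antiproliferative activity, read by MTT assay, with a stated time of 48 h; on this read-out higher numbers stand for weaker inhibition and lower numbers for stronger inhibition:

Compound 1 `COc1cc(-c2cccc3nc(-c4ccccc4)oc23)cc(OC)c1OC`: 20300 nM
Compound 2 `COc1cc(-c2cccc3nc(-c4ccc(F)cc4)oc23)cc(OC)c1OC`: 8700 nM
Compound 3 `COc1cc(-c2cccc3nc(-c4cccc(C)c4)oc23)cc(OC)c1OC`: 16700 nM

Compound 2 has the lowest of the three numbers in this assay. Its nearest neighbour is compound 3, with a 1.9-fold higher number from compound 2 to compound 3 (0.28 log units; within the scatter), a gap that stays within the scatter, while the gap to compound 1, a 2.3-fold lower number from compound 1 to compound 2 (0.37 log units; beyond the scatter), lies beyond it. Compound 4 `COc1cc(-c2cccc3nc(-c4cccs4)oc23)cc(OC)c1OC` has not yet been measured. It differs from compound 2 by thiophen-2-yl in place of 4-fluorophenyl on an aromatic carbon.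

Within the data shown here, two measured steps bear on this change. The step of a 2.3-fold lower number from compound 1 to compound 2 (0.37 log units; beyond the scatter) shows that the fluoro on the phenyl ring accounts for the modest advantage compound 2 holds, and the step of a 1.9-fold higher number from compound 2 to compound 3 (0.28 log units; within the scatter) shows that replacing the 4-fluorophenyl by a 3-methylphenyl costs little, within the scatter. Among the measured compounds shown here, no measured compound carries a thiophen-2-yl at this place, so the new ring itself is untested. Compound 4 loses the fluoro, and the precedent of compound 1 suggests the number rises somewhat, though a thiophen-2-yl is not a plain phenyl. The expected step in this assay is a 1.7-fold higher number from compound 2 to compound 4 (0.24 log units; within the scatter), a modest rise that could still fall inside the scatter. Compound 4 is therefore estimated at 15000 nM, with a range from 6000 nM to 40000 nM.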

Compound 4, half-maximal inhibitory concentration: 12500 nM
Beside the measured number, compound 4's estimate is 1.2-fold (0.08 log units) above it, and the stated range covers the measured number.
By their numbers in this assay, from the lowest: compounds 2, 4, 3 and 1 (each within the scatter of the next, the first and the last beyond it).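

In this assay, among these compounds, the earlier compounds varied only the substituents on a phenyl ring at this place, on the aromatic carbon next to the ring nitrogen and next to the ring oxygen; compound 4 shows that this six-membered ring of carbon can be exchanged for a five-membered aromatic ring holding sulfur with no difference that rises above the scatter. The exchange reads alike against all three earlier compounds, with a 1.4-fold higher number from compound 2 to compound 4 (0.16 log units; within the scatter) and a 1.3-fold lower number from compound 3 to compound 4 (0.13 log units; within the scatter) and also a 1.6-fold lower number from compound 1 to compound 4 (0.21 log units; within the scatter), so thiophen-2-yl cannot be ranked against 4-fluorophenyl, 3-methylphenyl or phenyl, even though the step between compound 1 and compound 2 lies beyond the scatter. Nothing measured here accounts for this result.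

From the compounds shown here alone, all four compounds carry an aromatic ring at this place, so it remains open whether a ring is needed there at all, or whether an amine, a carboxylic acid or a longer chain would give a number in the same range. Going by these compounds, it also remains open whether thiophen-3-yl, attached through the other ring carbon, would read like thiophen-2-yl.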